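The compounds below may be only part of what the source reports. "The series", "measured", "known", "first", "only" and "open" are said of these compounds alone.

Compound 1, `OC[C@H]1OC(n2cnc3c(-c4ccc(Cl)cc4)ncnc32)[C@H](O)[C@@H]1O` — in a functional assay on CCRF-CEM cells (Homo sapiens) for inhibition (on this read-out higher numbers stand for weaker inhibition and lower numbers for stronger inhibition), compound 1 gives 900 nM.
Compound 2, `OC[C@H]1OC(n2cnc3c(-c4ccccn4)ncnc32)[C@H](O)[C@@H]1O` — in this assay compound 2 gives 900 nM.

Compound 2 stands level with compound 1 on the numbers shown; the only measured step, no change at the digits printed from compound 1 to compound 2 (within the scatter), exchanged one aromatic group for another without moving the read-out beyond its scatter. Compound 3, `Cc1ccsc1-c1ncnc2c1ncn2C1O[C@H](CO)[C@@H](O)[C@H]1O`, is not yet measured. It differs from compound 2 by 3-methylthiophen-2-yl in place of pyridin-2-yl on an aromatic carbon. The single measured step bears on this change only loosely: it shows that swapping one six-membered aromatic group for another at this position left the inhibition unchanged, but a five-membered ring carrying a methyl group has no measured counterpart among these compounds. With nothing to suggest a shift, the expectation for compound 3 is a step of about no change at the digits printed from compound 2 to compound 3 (within the scatter), that is, none beyond the scatter, in this assay. Compound 3 is therefore estimated at 900 nM, with a range from 300 nM to 2700 nM.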

Compound 3, half-maximal inhibitory concentration: 2500 nM
Compound 3: middle estimate off by 2.8-fold (0.44 log units), on the low side; low and high end bracket the measured number.
By their numbers in this assay, from the lowest: compounds 1 and 2 (each within the scatter of the next); then compound 3.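

The position is not indifferent to every aromatic group: in this assay the read-out now moves, with a 2.8-fold higher number from compound 2 to compound 3 (0.44 log units; beyond the scatter) and a 2.8-fold higher number from compound 1 to compound 3 (0.44 log units; beyond the scatter), which means modestly weaker inhibition with 3-methylthiophen-2-yl than with either six-membered group. Pyridin-2-yl and 3-methylthiophen-2-yl have the same number of heavy atoms, so that count alone does not set the read-out at this carbon. No available evidence accounts for this shift.

The compounds shown leave open whether the step belongs to the five-membered ring, its sulfur or its methyl group, as these all change together. A plain thiophen-2-yl would separate the ring from the methyl, while an amine or a carboxylic acid on the same carbon would test whether this position needs an aromatic group at all.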